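Removing the para chloro from compound 2: expected outcome

The source may hold more compounds than are shown below. What is called first, only, known or untested is meant among the compounds shown, and "the series" means these compounds.

Measured compounds:
- compound 1, `O=C(Nc1ccc(Oc2ccnc3[nH]ccc23)cc1)c1cc(-c2ccc(F)cc2)ncn1`: 15900 nM
- compound 2, `O=C(Nc1ccc(Oc2ccnc3[nH]ccc23)cc1)c1cc(-c2ccc(Cl)cc2)ncn1`: 7770 nM

Both compounds were tested in a functional assay on MCF7 cells (Homo sapiens) for cytotoxicity, read by MTT assay, with a stated time of 72 h; on this read-out higher numbers stand for weaker inhibition and lower numbers for stronger inhibition. Among the compounds with values here, compound 1 gives 15900 nM there, while compound 2 gives 7770 nM, the lower of the two numbers; the only measured step, a 2.0-fold lower number from compound 1 to compound 2 (0.31 log units; beyond the scatter), arises from a chloro in place of fluoro on an aromatic carbon.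

Compound 3, `O=C(Nc1ccc(Oc2ccnc3[nH]ccc23)cc1)c1cc(-c2ccccc2)ncn1`, has not yet been measured. It differs from compound 2 by hydrogen in place of chloro on an aromatic carbon: on an aromatic carbon of a six-membered aromatic ring of carbon only, para to a large group, so that the 4-chlorophenyl becomes a plain phenyl.

Within the data shown here, the one known step shows that exchanging one halogen for another at this position shifts the number modestly. Taking away the halogen altogether has no measured counterpart here, so the direction is uncertain; given that compound 1 with the smaller halogen sits at 15900 nM, the number for compound 3 is expected to move back upward, a 1.9-fold higher number from compound 2 to compound 3 (0.29 log units; within the scatter). The estimate for compound 3 is 15000 nM, with a range from 6000 nM to 40000 nM.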

Compound 3, half-maximal inhibitory concentration: 20 nM
Compound 3: middle estimate off by 750-fold (2.88 log units), on the high side; measured number below the stated range.
By their numbers in this assay, from the lowest: compound 3; then compound 2; then compound 1.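

In this assay, what matters at this place on the ring is whether a halogen is present at all, not which one: going to the plain phenyl gives a large step (a 390-fold lower number from compound 2 to compound 3 (2.59 log units; beyond the scatter)), and the fluoro compound gives a similarly large one (an 800-fold lower number from compound 1 to compound 3 (2.90 log units; beyond the scatter)). The exchange of one halogen for the other had moved the number far less (a 2.0-fold lower number from compound 1 to compound 2 (0.31 log units; beyond the scatter)), so the two halogen compounds alone gave no sign of how much lower the number could go. Nothing measured here explains why a hydrogen in place of chloro or fluoro has so large an effect.

On these data alone, only hydrogen, fluoro and chloro appear on this carbon, so it remains open whether a methyl, a methoxy or an amine there would keep the low number of compound 3 or lose it as the halogens do. Only this assay is shown, so whether compound 3 keeps its lead over the halogen compounds in other cells also stays open.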